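This account rests on a few compounds, and the source may have more. Where it says the series, first, only, none or still open, it means among the compounds named here.

Measured in a functional assay on HaCaT cells (Homo sapiens) for cytotoxicity, with a stated time of 48 h; a lower number here means a stronger inhibitor, a higher number a weaker inhibitor:

Compound 1 `COc1cc(O)c(C(=O)/C=C/c2ccc(F)cc2)c(OC)c1`: > 20000 nM (a limit of the assay)
Compound 2 `COc1cc(OC)c(C(=O)/C=C/c2ccccc2)c(OC)c1`: 7200 nM
Compound 3 `COc1cc(O)c(C(=O)/C=C/c2ccccc2OC)c(OC)c1`: 10900 nM

Compound 2 holds one of the two actual numbers in this small set. At 7200 nM, compound 2 lies within the usual scatter of compound 3 at 10900 nM, so the two cannot be ranked. Compound 1 reached only a limit, > 20000 nM, and so gives no number to compare.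

The next compound, compound 4 `COc1cc(OC)c(C(=O)/C=C/c2ccc(Br)cc2)c(OC)c1`, has not yet been measured. It differs from compound 2 by a single change, bromo in place of hydrogen on an aromatic carbon, para to a large group, which turns phenyl into 4-bromophenyl (bromo in place of hydrogen on an aromatic carbon).

Among the compounds with values here, no measured pair in the set differs in only one place, so the data offer no direct guide to this change. The expectation is therefore a step no larger than the scatter in this assay, with no firm direction. The estimated change is a 1.1-fold lower number from compound 2 to compound 4 (0.04 log units; within the scatter). For compound 4 the expected value is 6500 nM, with an estimated range from 2200 nM to 19000 nM.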

Compound 4, half-maximal inhibitory concentration: 9000 nM
Estimate against measurement, compound 4: 1.4-fold (0.14 log units) below; the range from low to high includes it.
By their numbers in this assay, from the lowest: compounds 2, 4 and 3 (each within the scatter of the next). At a limit, above all of these: compound 1.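

Within the data shown here, compound 2 and compound 4 form the first pair in this set that differs in only one place, and in this assay that pair gives a direct reading for the bromo group: a 1.3-fold higher number from compound 2 to compound 4 (0.10 log units; within the scatter). At this place, on an aromatic carbon para to a large group, putting bromo in place of hydrogen therefore yields two compounds that cannot be told apart in this assay, which turns the earlier lack of any guide for this replacement into one measured, though small, step. Compound 1 remains the only compound at a limit, and compound 4 does not join it, since compound 4 returns an actual number: the limit of > 20000 nM in this assay, at which 1 of the 4 values shown sits.

This single pair speaks only for bromo at this one place on the core of compound 2, so it leaves open whether an amine, a carboxylic acid or a longer chain at the same place would also stay within the scatter of compound 2. It also leaves open whether bromo would give a similar reading on a core that carries a hydroxyl group in place of one of the methoxy groups.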